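The compounds below may be only part of what the source reports. "The series", "measured", "known", "first", "only" and "open" are said of these compounds alone.

Measured so far, in a functional assay on the whole organism (strain albino) for inhibition, with Rattus norvegicus as the target, read by paw edema, with stated times of 1 h and 2 h, at a dose of 100 mg/kg by the oral route; a lower number here means less inhibition, a higher number more inhibition at the dose given (going by the name of the read-out):
- compound 1, `N#Cc1c(-c2ccccc2)nc(SCC(=O)Nn2c(COc3ccc(Cl)cc3Cl)nc3ccccc3c2=O)n(Cc2ccccc2)c1=O`, gives 79%
- compound 2, `N#Cc1c(-c2ccc(Cl)cc2)nc(SCC(=O)Nn2c(COc3ccc(Cl)cc3Cl)nc3ccccc3c2=O)n(Cc2ccccc2)c1=O`, gives 77.2%
- compound 3, `N#Cc1c(Nc2ccccc2)nc(SCC(=O)Nn2c(COc3ccc(Cl)cc3Cl)nc3ccccc3c2=O)nc1-c1ccc(Cl)cc1`, gives 50.9%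

Compound 2 differs from compound 1 only by chloro in place of hydrogen on an aromatic carbon, and this step was a number 1.8 percentage points lower from compound 1 to compound 2 (within the scatter), so the two values sit together. Compound 3 has a different core from compound 1, and the difference between the two cores is not broken down here. Compound 3 stands lowest of the three; its value lies beyond the usual scatter below both compound 2 and compound 1.

Compound 4, `N#Cc1c(Nc2ccc(Cl)cc2)nc(SCC(=O)Nn2c(COc3ccc(Cl)cc3Cl)nc3ccccc3c2=O)nc1-c1ccc(Cl)cc1`, is not yet measured. It differs from compound 3 by chloro in place of hydrogen on an aromatic carbon, which is the same change as that from compound 1 to compound 2. Since that earlier step was a number 1.8 percentage points lower from compound 1 to compound 2 (within the scatter), a small step is expected here as well, and compound 4 is expected to stay close to compound 3. The expected step is a number 1.9 percentage points lower from compound 3 to compound 4 (within the scatter). Compound 4 is therefore estimated at 49%, most likely between 36% and 62%.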

Compound 4, a percentage reported as inhibition, in the whole organism at one dose (the size of the read-out at that dose, not a potency): 61.4%
For compound 4 the middle estimate is 12.4 percentage points below the measured one, and the stated range covers the measured number.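

In this assay, putting chloro in place of hydrogen on the anilino group of compound 3 gives a number 10.5 percentage points higher from compound 3 to compound 4 (beyond the scatter). Set beside the same change on the other core, the two steps cannot be told apart, even though one lies within the scatter and the other beyond it: the same change on two cores in this assay, a number 1.8 percentage points lower (within the scatter) from compound 1 to compound 2 and a number 10.5 percentage points higher (beyond the scatter) from compound 3 to compound 4, 12.3 percentage points apart, within the scatter of two such steps. For the compounds shown here, this means that nothing here argues against carrying the change from one core to the other, but it does not prove that the change acts the same way on both, since there are only two pairs, the chloro sits on a different group in each, and a single oral dose gives the size of the read-out rather than a potency.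

On these data alone, it remains open whether the small rise seen with compound 4 would hold up on further cores. The compounds shown also leave open what a group other than chloro, such as methoxy or an amine, would do in the same place on the anilino group.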